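Ethyl to methyl on an amine nitrogen in a ring

The source may report more compounds than this note shows. Statements on the series, on what has been measured and on what is new or still open speak of the compounds shown alone.

In a functional assay (strain AB) with Danio rerio as the target, read by microscopy, with a stated time of 1 h (on this read-out lower numbers stand for an effect already at smaller amounts and higher numbers for an effect only at larger amounts of compound), compound 3 `CC[N+]1(CC2CC2)CCc2c(sc(NC(=O)Nc3ccc(Cl)cc3)c2C(N)=O)C1` gives 100 nM. Compound 1 `CC(C)(C)OC(=O)CCCC[N+]1(C)CCc2c(sc(NC(=O)Nc3ccc(Cl)cc3)c2C(N)=O)C1` gives 140 nM, within the usual scatter of compound 3, while compound 2 `CC(C)[N+]1(C)CCc2c(sc(NC(=O)Nc3ccc(Cl)cc3)c2C(N)=O)C1` gives a clearly higher 960 nM.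

Compound 4 `C[N+]1(CC2CC2)CCc2c(sc(NC(=O)Nc3ccc(Cl)cc3)c2C(N)=O)C1` differs from compound 3 by one small change: hydrogen in place of methyl on a saturated chain carbon bound to an amine nitrogen in a ring. This places hydrogen in place of methyl on a saturated chain carbon bound to an amine nitrogen in a ring, so ethyl becomes methyl. Among the compounds with values here, no measured step makes this exact change. The closest evidence is a 6.9-fold higher number from compound 1 to compound 2 (0.84 log units; beyond the scatter), where isopropyl replaces 4-(tert-butoxycarbonyl)butyl on an amine nitrogen in a ring. That step shows that a swap at this nitrogen can go beyond the scatter, but it is a much larger swap and gives no firm direction here. Only a small shift towards a higher number is therefore expected. The expected step is a 1.7-fold higher number from compound 3 to compound 4 (0.23 log units; within the scatter). The estimate for compound 4 is 170 nM, with an expected range from 60 nM to 500 nM.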

Compound 4, half-maximal effective concentration: 360 nM
For compound 4 the middle estimate is 2.1-fold (0.33 log units) below the measured one; low and high end bracket the measured number.
By their numbers in this assay, from the lowest: compounds 3 and 1 (each within the scatter of the next); then compound 4; then compound 2.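

In this assay, the small change from ethyl to methyl on the amine nitrogen in a ring, with cyclopropylmethyl kept, moves the number beyond the scatter, with a 3.6-fold higher number from compound 3 to compound 4 (0.56 log units; beyond the scatter), so even this trim is not silent at this position. With methyl kept on that nitrogen, the other group also counts: cyclopropylmethyl in place of isopropyl gives a 2.7-fold lower number from compound 2 to compound 4 (0.43 log units; beyond the scatter), while the swap away from the long ester chain gives a 2.6-fold higher number from compound 1 to compound 4 (0.41 log units; beyond the scatter), placing the cyclopropylmethyl compound between the two. Nothing measured here explains why these changes shift the number.

From the compounds shown here alone, with only ethyl and methyl tested beside cyclopropylmethyl, it stays open whether a propyl group or a longer chain would lower the number further or raise it again. Going by these compounds, it is also open whether a carboxylic acid in place of the tert-butyl ester would keep the low number of the long chain.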